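A few compounds are considered here, and "the series" means these few. Any claim that something is new, unique, unknown or untested is made for them only; others in the source may bear on it.

In an ADME assay on BJ cells (Homo sapiens) for antiproliferative activity, with a stated time of 72 h (a lower number here means that less compound is needed, a higher number that more compound is needed for the effect), compound 3 `COc1ccc(-c2cc(=O)c3c(OC)cc(OC)cc3n2S(=O)(=O)c2ccc(C)cc2)cc1` reaches only a limit of the assay, > 44800 nM. Its two measured relatives stand the same way. Compound 1 `COc1ccc(-c2cc(=O)c3c(OC)cc(OC)cc3n2S(=O)(=O)c2cc(F)c(F)c(F)c2)cc1` gives a limit, > 65500 nM. Compound 2 `COc1ccc(-c2cc(=O)c3c(OC)cc(OC)cc3n2S(=O)(=O)c2cccc(Br)c2)cc1` gives a limit, > 58600 nM. The three steps among them, a step that the two limits leave unreadable from compound 1 to compound 2, a step that the two limits leave unreadable from compound 1 to compound 3 and a step that the two limits leave unreadable from compound 2 to compound 3, therefore have no readable size, and the three limits (the limit of > 44800 nM in this assay, at which 1 of the 3 values shown sits), the limit of > 58600 nM in this assay, at which 1 of the 3 values shown sits, and the limit of > 65500 nM in this assay, at which 1 of the 3 values shown sits, are all the evidence there is. Compound 4 `COc1ccc(-c2cc(=O)c3c(OC)cc(OC)cc3n2S(=O)(=O)Cc2ccccc2)cc1` arises from compound 3 by the change (benzyl in place of 4-methylphenyl on a sulfonyl sulfur). Three sulfonyl variants all ending at a limit make another limit, rather than a number, the expected outcome. The estimate for compound 4 in this assay is 50000 nM, between 15000 nM and 200000 nM. This corresponds to an expected step that the limit leaves unreadable from compound 3 to compound 4.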

Compound 4, half-maximal effective concentration: > 34400 nM
Compound 4 was reported as a limit; the forecaster's own chance of this, stated with the estimate: 75%; the middle value lies beyond the limit too.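

Compound 4 also ends at a limit in this assay, > 34400 nM, so its steps from compound 1, compound 2 and compound 3 cannot be read. The compounds shown leave open whether these sulfonyl groups differ in effect at all.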